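Working notes: from compound 1 to compound 4

The compounds below may be only part of what the source reports. "The series", "measured", "known", "first", "only" and "open" are said of these compounds alone.

Of the compounds shown here, three have been measured in a functional assay on MGC-803 cells (Homo sapiens) for antiproliferative activity, read by CCK-8 assay, with a stated time of 72 h, tested at 2 uM; on this read-out higher numbers stand for a stronger effect at the one concentration tested and lower numbers for a weaker effect. Compound 1 `Nc1ccccc1NC(=O)c1ccc(CSC(=S)N2CCN(C3CCCCC3)CC2)cc1` gives 16.9% in this assay, the lowest of the three numbers. Compound 2 `Nc1ccccc1NC(=O)c1ccc(CSC(=S)N2CCc3cc([N+](=O)[O-])ccc32)cc1` gives 26.8%, a number that lies within the scatter of the value of compound 1. Compound 3 `Nc1ccccc1NC(=O)c1ccc(CSC(=S)N2CCCc3ccccc32)cc1` gives 38.5%, and its gap to compound 1 lies beyond the scatter. Going by the values given here, no pair among the measured compounds differs in a single place, so no measured step exists from which the effect of one change on this read-out could be read.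

Compound 4 `Nc1ccccc1NC(=O)c1ccc(CSC(=S)N2CCN(c3ncccn3)CC2)cc1` is not yet measured. It differs from compound 1 in one place: pyrimidin-2-yl in place of cyclohexyl on an amine nitrogen in a ring. The measured compounds give no guide to this particular exchange; compounds 2 and 3 carry other groups at that part of the shared core, and their values cannot be assigned to any single change. The step from compound 1 to compound 4 is therefore expected to be small, a number 5.1 percentage points higher from compound 1 to compound 4 (within the scatter), and not beyond the scatter in either direction. On that basis compound 4 is estimated at 22% in this assay, with a range from 8% to 40%.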

Compound 4, a percentage reported as inhibition, at one concentration (the size of the read-out at that concentration, not a potency): 28.4%
For compound 4 the middle estimate is 6.4 percentage points below the measured one; low and high end bracket the measured number.
By their numbers in this assay, from the lowest: compounds 1, 2 and 4 (each within the scatter of the next, the first and the last beyond it); then compound 3.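

In this assay, going by these compounds alone, pyrimidin-2-yl in place of cyclohexyl on an amine nitrogen in a ring gives the first step that can be read for a single change: a number 11.5 percentage points higher from compound 1 to compound 4 (beyond the scatter). This modest step shows that the read-out responds to the group at this position, even though both groups have 6 heavy atoms; the entering group brings an aromatic ring with 2 hetero atoms and 2 hydrogen-bond acceptors, where the leaving group has a ring of carbon only and no acceptors. Nothing measured here accounts for the step or assigns it to any one of these differences.

The compounds shown leave open whether the step goes with the aromatic ring as such or with its ring nitrogens; phenyl or pyridin-2-yl on the same amine nitrogen would bear on that question. Also open, going by these compounds, is how the step would read as a potency, as this read-out gives only the size of an effect at one concentration.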